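Swapping an anilino group for a pyridinylpiperazine on the core

The source may report more compounds than this note shows. Statements on the series, on what has been measured and on what is new or still open speak of the compounds shown alone.

Of the compounds shown here, three with a shared core have been tested in a functional assay on MDA-MB-231 cells (Homo sapiens) for inhibition, with a stated time of 72 h; on this read-out higher numbers stand for weaker inhibition and lower numbers for stronger inhibition. Compound 1 `COc1ccc(NC(=O)Nc2nc(Sc3c[nH]c4ccccc34)cc(N3CCN(c4ccccn4)CC3)n2)cc1` gives 28400 nM in this assay. Compound 2 `O=C(Nc1ccccc1)Nc1nc(NC2CC2)cc(Sc2c[nH]c3ccccc23)n1` gives 7860 nM, and compound 3 `O=C(Nc1ccccc1)Nc1nc(Nc2ccc(Cl)cc2)cc(Sc2c[nH]c3ccccc23)n1` gives 10300 nM. Compound 3 thus stands second highest of the three numbers: its gap to compound 2 lies within the scatter, while its gap to compound 1 lies beyond it. Among the compounds with values here, the only step between two measured compounds that differ in one place is a 1.3-fold higher number from compound 2 to compound 3 (0.12 log units; within the scatter), an exchange that left the number inside the scatter.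

Compound 4 `O=C(Nc1ccccc1)Nc1nc(Sc2c[nH]c3ccccc23)cc(N2CCN(c3ccccn3)CC2)n1` is the next compound. It differs from compound 3 in one place: 4-(pyridin-2-yl)piperazin-1-yl in place of (4-chlorophenyl)amino on an aromatic carbon. Within the data shown here, no measured step covers this exact exchange. Compound 1, however, carries the same 4-(pyridin-2-yl)piperazin-1-yl group on the same core and differs from compound 4 only by a methoxy group, so its number is the closest guide. Weaker inhibition is therefore expected, since compound 1 gives 28400 nM with that group in place. Compound 4 is expected to give about 22000 nM in this assay, with a range from 8000 nM to 55000 nM. The estimate for compound 4 thus means a 2.1-fold higher number from compound 3 to compound 4 (0.33 log units; beyond the scatter).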

Compound 4, half-maximal inhibitory concentration: 19500 nM
Compound 4: middle estimate off by 1.1-fold (0.05 log units), on the high side; low and high end bracket the measured number.
By their numbers in this assay, from the lowest: compounds 2, 3, 4 and 1 (each within the scatter of the next, the first and the last beyond it).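

In this assay, placing 4-(pyridin-2-yl)piperazin-1-yl on the aromatic carbon in place of (4-chlorophenyl)amino gives a 1.9-fold higher number from compound 3 to compound 4 (0.28 log units; within the scatter), so this read-out does not clearly separate these two groups, even though the entering group has no hydrogen-bond donor and the leaving group has one. Placing the same group there in place of cyclopropylamino gives a 2.5-fold higher number from compound 2 to compound 4 (0.39 log units; beyond the scatter), a modest change and the only step at this position so far that clears the scatter. Hydrogen in place of methoxy on an aromatic carbon gives a 1.5-fold lower number from compound 1 to compound 4 (0.16 log units; within the scatter), so with 4-(pyridin-2-yl)piperazin-1-yl in place, this methoxy group makes no difference that the read-out can separate.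

No measurement shown here explains these numbers. Going by these compounds, it remains open how a morpholine or a simple dimethylamino group at this same carbon would compare, and whether any group there could move the number well beyond the scatter in the direction of stronger inhibition.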